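From a limit value to an ethylphenyl sulfonamide

The source may hold more compounds than are shown below. What is called first, only, known or untested is meant among the compounds shown, and "the series" means these compounds.

Three sulfonamides sharing one core have been read so far. In an ADME assay on HEK293 cells (Homo sapiens) for cytotoxicity, read by resazurin assay, with a stated time of 48 h (on this read-out higher numbers stand for lower toxicity in this test and lower numbers for higher toxicity in this test), compound 1 `C=Cc1ccc(S(=O)(=O)Nc2ccc3oc(-c4ccccc4)nc3c2)cc1`, which carries 4-vinylphenyl on the sulfonyl sulfur, gives 53000 nM. Compound 2 `O=S(=O)(Nc1ccc2oc(-c3ccccc3)nc2c1)c1ccccc1F` gives 72000 nM. Compound 3 `O=S(=O)(Nc1ccc2oc(-c3ccccc3)nc2c1)c1cccc(O)c1` stands at a limit of the assay and not at a number, > 100000 nM.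

The next compound, compound 4 `CCc1ccc(S(=O)(=O)Nc2ccc3oc(-c4ccccc4)nc3c2)cc1`, has not yet been measured. It has 4-ethylphenyl in place of the 3-hydroxyphenyl of compound 3, on a sulfonyl sulfur whose other neighbours are: sulfonamide nitrogen (4-ethylphenyl in place of 3-hydroxyphenyl on a sulfonyl sulfur).

All three measured steps change the group at this same place. They are a 1.4-fold higher number from compound 1 to compound 2 (0.13 log units; within the scatter), an at least 1.8-fold higher number from compound 1 to compound 3 (0.27 log units; that floor lies within the scatter) and an at least 1.3-fold higher number from compound 2 to compound 3 (0.14 log units; that floor lies within the scatter). On these data alone, the last two rest on the limit of compound 3, so their true size remains open. Among the measured groups, 4-vinylphenyl is the closest by name to 4-ethylphenyl, which makes compound 1 at 53000 nM the main guide. A move to a lower number in this assay is therefore expected, of about the size seen between compound 1 and compound 3. The estimated step is an at least 1.8-fold lower number from compound 3 to compound 4 (0.25 log units; that floor lies within the scatter). For compound 4 the expected value is 55000 nM, with an estimated range from 28000 nM to 100000 nM.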

Compound 4, half-maximal cytotoxic concentration: 81000 nM
For compound 4 the middle estimate is 1.5-fold (0.17 log units) below the measured one, and the stated range covers the measured number.
By their numbers in this assay, from the lowest: compounds 1, 2 and 4 (each within the scatter of the next). At a limit, above all of these: compound 3.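

Ethyl in place of vinyl on an aromatic carbon is the smallest change at this position so far, and in this assay it gives a 1.5-fold higher number from compound 1 to compound 4 (0.18 log units; within the scatter), so the vinyl group is not required for a reading in this range. The exchange of a whole group gives a 1.1-fold higher number from compound 2 to compound 4 (0.05 log units; within the scatter), and with this the three compounds that read as numbers cannot be put in any order, although their groups on the sulfonyl sulfur differ in kind and in where the group stands on the phenyl ring. On these data alone, the remaining step is an at least 1.2-fold lower number from compound 3 to compound 4 (0.09 log units; that floor lies within the scatter), and its true size stays open because the value of compound 3 is a limit and not a number: the limit of > 100000 nM in this assay, at which 1 of the 4 values shown sits.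

Whether 3-hydroxyphenyl, the only group shown with a hydrogen-bond donor, truly stands apart from the others therefore remains unsettled. What an aminophenyl group, a carboxyphenyl group or a phenyl ring bearing a longer chain would give on the sulfonyl sulfur in this assay is also left open, as is any change to the shared core.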